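From Furan to 4-Chlorophenyl at the Assay Limit

This account rests on a few compounds, and the source may have more. Where it says the series, first, only, none or still open, it means among the compounds named here.

In a functional assay on K562 cells (Homo sapiens) for antiproliferative activity, read by MTT assay, with a stated time of 24 h (a higher number here means a weaker inhibitor, a lower number a stronger inhibitor), compound 3 (`COc1ccc(C(=O)/C=C/c2ccco2)c2c1C=CC(C)(C)O2`) gives > 10000 nM as a limit and not a number. Compound 3 thus sits at the limit of > 10000 nM in this assay, at which 2 of the 3 values shown sit, and has no exact position. Compound 1 (`COc1ccc(C(=O)/C=C/c2ccc(F)cc2)c2c1C=CC(C)(C)O2`) gives > 10000 nM as a limit too. Only compound 2 (`CCN(CC)c1ccc(/C=C/C(=O)c2ccc(OC)c3c2OC(C)(C)C=C3)cc1`) gives a number, 790 nM in this test. Compound 4 (`COc1ccc(C(=O)/C=C/c2ccc(Cl)cc2)c2c1C=CC(C)(C)O2`) has 4-chlorophenyl in place of furan-2-yl (4-chlorophenyl in place of furan-2-yl on a double-bonded chain carbon bound to a double-bonded chain carbon) on a double-bonded chain carbon bound to a double-bonded chain carbon. The closest comparison is a step that the two limits leave unreadable from compound 1 to compound 3 and tells little. The large at least 12-fold lower number from compound 1 to compound 2 (1.10 log units; beyond the scatter) came with diethylamino, which compound 4 lacks. The expected change in this assay is a number no higher from compound 3 to compound 4 (the limit leaves the size open) and none beyond the scatter. Compound 4 is estimated at 10000 nM within a range of 3000 nM to 30000 nM, and a limit rather than a number is expected for it.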

Compound 4, half-maximal inhibitory concentration: > 10000 nM
Compound 4: a limit, no number (the forecaster's own chance of this, stated with the estimate: 70%); the middle value sits exactly at the limit.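

Chloro in place of diethylamino on an aromatic carbon gives an at least 12-fold higher number from compound 2 to compound 4 (1.10 log units; beyond the scatter), so compound 2 now stands apart from two halogen-bearing compounds rather than one. The steps joining compound 1, compound 3 and compound 4 run from limit to limit and cannot be read. Compound 4 gives only a limit, and most of the series now gathers there: the limit of > 10000 nM in this assay, at which 3 of the 4 values shown sit.

As far as these compounds go, how far past that limit these compounds lie stays open. Also open, from the compounds shown here alone, is whether another amine on that aromatic carbon, such as dimethylamino or piperidine, would give a number as diethylamino does.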